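Configuration change at the top of the cytotoxicity range

The compounds below may be only part of what the source reports. "The series", "measured", "known", "first", "only" and "open" are said of these compounds alone.

Measured so far:
- compound 1 `Nc1nc2c(ncn2/C=C2\C[C@@H]2[C@H](O)CO)c(=O)[nH]1`: > 300000 nM (a limit)
- compound 2 `Nc1nc2c(ncn2/C=C2/CC2(CO)CO)c(=O)[nH]1`: > 100000 nM (a limit)

In an ADME assay on HFF cells (Homo sapiens) for cytotoxicity, read by neutral red uptake (a lower number here means that less compound is tolerated, a higher number that more compound is tolerated), compound 1 gives > 300000 nM, which is a limit of the assay and not a number. Compound 2 gives > 100000 nM, and this is also a limit. For the measured compounds named here, the two values therefore cannot be ranked, and the series has no measured step yet.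

Compound 3 `Nc1nc2c(ncn2/C=C2/C[C@H]2[C@H](O)CO)c(=O)[nH]1` has the same atoms and bonds as compound 1 and differs only in configuration as drawn: the two compounds have the same atoms and bonds and differ only in configuration as drawn: 2 of 3 stereo elements differ; a stereocentre at a saturated ring carbon is drawn S in compound 1 and R in compound 3; a double bond is drawn E in compound 1 and Z in compound 3. A stereocentre at a saturated ring carbon is drawn S in compound 1 and R in compound 3, and a double bond is drawn E in compound 1 and Z in compound 3.

Going by the values given here, with no measured step to draw on, no change beyond the scatter is expected in this assay, in either direction. This expectation rests on compound 1, with its limit of > 300000 nM. The expected change is a number no higher from compound 1 to compound 3 (the limit leaves the size open). A limit is again the likeliest report. For compound 3 the estimated value is 300000 nM, with an expected range of 100000 nM to 600000 nM.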

Compound 3, half-maximal cytotoxic concentration: > 300000 nM
Compound 3 was reported as a limit; the forecaster's own chance of this, stated with the estimate: 85%; the middle value lies on the limit itself.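

No step from compound 1 to compound 3 can be read, since both compounds are reported only as limits: the limit of > 300000 nM in this assay, at which 2 of the 3 values shown sit.

The compounds shown leave open whether the drawn changes at the saturated ring carbon stereocentre and the double bond make any difference in this assay, and how far any compound's true value lies past its limit.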